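This account rests on a few compounds, and the source may have more. Where it says the series, first, only, none or still open, it means among the compounds named here.

Of the compounds shown here, three have been measured in a functional assay on HL-60 cells (Homo sapiens) for inhibition, read by MTT assay, with a stated time of 72 h; on this read-out higher numbers stand for weaker inhibition and lower numbers for stronger inhibition. Compound 1, with structure `Cc1nc(-c2ccccc2)c(C(=O)N2CCN(c3cccc(C(F)(F)F)c3)CC2)o1`, gives 153 nM in this assay. Compound 2, with structure `Cc1ccc(C)c(N2CCN(C(=O)c3oc(C)nc3-c3ccc(F)cc3)CC2)c1`, gives 358 nM. Compound 3, with structure `COc1cc(OC)cc(N2CCN(C(=O)c3onc(C)c3-c3ccc(-c4ccco4)cc3)CC2)c1`, gives 191 nM. Compound 1 thus shows the lowest of the three numbers, but the gap to compound 3 lies within the usual scatter of repeated measurements, so the two cannot be told apart; only the gap to compound 2 lies beyond it.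

Compound 4, with structure `Cc1cc(C)cc(N2CCN(C(=O)c3oc(C)nc3-c3ccccc3)CC2)c1`, has not yet been measured. It differs from compound 1 in one place: 3,5-dimethylphenyl in place of 3-(trifluoromethyl)phenyl on an amine nitrogen in a ring. Among the measured compounds shown here, no measured pair shows this exact change, so the effect has to be estimated from the numbers at hand. Compound 2, which also carries a dimethyl-substituted phenyl on the ring nitrogen, gave 358 nM, a somewhat higher number than compound 1. A small shift toward weaker inhibition, close to the edge of the scatter, is therefore expected: the step from compound 1 to compound 4 is estimated as a 1.7-fold higher number from compound 1 to compound 4 (0.23 log units; within the scatter). For compound 4 the expected value in this assay is 260 nM, with a plausible range from 90 nM to 750 nM.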

Compound 4, half-maximal inhibitory concentration: 34.5 nM
Compound 4: middle estimate off by 7.5-fold (0.88 log units), on the high side; the whole stated range lies above it.
By their numbers in this assay, from the lowest: compound 4; then compounds 1, 3 and 2 (each within the scatter of the next, the first and the last beyond it).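

In this assay, putting 3,5-dimethylphenyl in place of 3-(trifluoromethyl)phenyl on the ring nitrogen gives a 4.4-fold lower number from compound 1 to compound 4 (0.65 log units; beyond the scatter) and so moves the result beyond the usual scatter. The earlier compounds shown here could not show this, as no two of them differed in one place only; this pair shows that, with the rest of the molecule held constant, the choice of phenyl group at this nitrogen alone can change the read-out. Nothing at hand explains why the number falls.

This single step swaps the whole group, so it cannot separate losing the trifluoromethyl group from gaining the dimethyl pattern. A plain phenyl or a 3-methylphenyl on the same nitrogen would help to tell these two parts apart.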